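Coumarin Imines Against Myosin-2: From Pyridylmethyl to Methylbenzyl

This account rests on a few compounds, and the source may have more. Where it says the series, first, only, none or still open, it means among the compounds named here.

Compound 1, `C/C(=N\C(C)C)c1c(O)c2ccccc2oc1=O`, in an assay on isolated protein for inhibition of myosin-2 (Bos taurus), read by spectrophotometry, with a stated time of 24 min (a higher number here means a weaker inhibitor, a lower number a stronger inhibitor), gives only a limit of that assay, >= 100000 nM.
Compound 2, `CCC(C)/N=C(\C)c1c(O)c2ccccc2oc1=O`, in this assay likewise gives only a limit, >= 100000 nM.
Compound 3, `C/C(=N\Cc1ccccn1)c1c(O)c2ccccc2oc1=O`, in this assay gives 22000 nM.

Within the data shown here, compound 3 therefore holds the only number among the three measured compounds; the other two sit at the limit of >= 100000 nM in this assay, at which 2 of the 3 values shown sit. The two readable steps both lead to compound 3: an at least 4.5-fold lower number from compound 1 to compound 3 (0.65 log units; beyond the scatter) and an at least 4.5-fold lower number from compound 2 to compound 3 (0.65 log units; beyond the scatter), each swapping a branched alkyl on the double-bonded nitrogen for (pyridin-2-yl)methyl.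

Compound 4, `C/C(=N\Cc1ccc(C)cc1)c1c(O)c2ccccc2oc1=O`, keeps that arrangement but changes the aromatic group: 4-methylphenyl in place of pyridin-2-yl on a saturated chain carbon bound to a double-bonded nitrogen. Among the measured compounds shown here, no measured step touches this exchange, so the steps from compound 1 and compound 2 inform only indirectly; they show that a methylene-linked aromatic ring on the nitrogen gave a number where alkyls gave none, but not whether the nitrogen within the ring mattered.

Compound 4 is therefore estimated to lie near compound 3, with a step of a 1.6-fold higher number from compound 3 to compound 4 (0.20 log units; within the scatter) expected in this assay. The estimate for compound 4 in this assay is 35000 nM, with a range from 8000 nM to 100000 nM, and a real chance that only a limit is recorded.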

Compound 4, half-maximal inhibitory concentration: 7900 nM
Estimate against measurement, compound 4: 4.4-fold (0.65 log units) above, outside the stated range (below it).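

In this assay the exchange of pyridin-2-yl for 4-methylphenyl on a saturated chain carbon bound to a double-bonded nitrogen gives a 2.8-fold lower number from compound 3 to compound 4 (0.44 log units; beyond the scatter) and so shows that the ring nitrogen of compound 3 is not required for a measurable number at this position. An aromatic ring of carbon only, in a group with no hydrogen-bond acceptor, gives a number here as well, and a lower one. Compound 1 and compound 2 remain limits rather than numbers, so only compound 3 and compound 4 can be ranked against each other: the limit of >= 100000 nM in this assay, at which 2 of the 4 values shown sit.

This one exchange removes the ring nitrogen and adds a methyl together, so the compounds shown cannot separate the two. Unsubstituted phenyl on the same chain carbon would divide that step, while 4-methoxyphenyl, 4-chlorophenyl and a longer chain carrying the ring also remain open.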